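A few compounds are considered here, and "the series" means these few. Any claim that something is new, unique, unknown or untested is made for them only; others in the source may bear on it.

Compound 1 `CON(C)C(=O)c1ccc(-c2ccc(OCC3CCN(C(=O)OC(C)(C)C)CC3)cn2)cc1` and compound 2 `CON(C)C(=O)c1ccc(-c2ccc(OCC3CCN(C(=O)OC(C)(C)C)CC3)cn2)cc1F` share one core and differ only where a fluoro replaces hydrogen on an aromatic carbon. In a functional assay on cells for agonist activity at Glucose-dependent insulinotropic receptor (Homo sapiens), read by a luciferase reporter, with a stated time of 6 h (on this read-out higher numbers stand for an effect only at larger amounts of compound and lower numbers for an effect already at smaller amounts), compound 1 gives 171 nM, and compound 2 gives 73 nM, so that a 2.3-fold lower number from compound 1 to compound 2 (0.37 log units; beyond the scatter). Compound 2 thus holds the lower of the two numbers. Compound 3 `CCc1cnc(N2CCC(COc3ccc(-c4ccc(C(=O)N(C)OC)c(F)c4)nc3)CC2)nc1` carries 5-ethylpyrimidin-2-yl in place of tert-butoxycarbonyl on an amine nitrogen in a ring. Among the compounds with values here, no measured step touches this part of the molecule, and the single known step concerns a different position, so nothing here sets the direction or size of the change. Compound 3 is estimated at 40 nM in this assay, within 8 nM to 200 nM, an expected step of a 1.8-fold lower number from compound 2 to compound 3 (0.26 log units; within the scatter).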

Compound 3, half-maximal effective concentration: 77 nM
The estimate for compound 3 lay 1.9-fold (0.28 log units) below the measured number, within the range that was stated.
By their numbers in this assay, from the lowest: compounds 2 and 3 (each within the scatter of the next); then compound 1.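

In this assay, the amine nitrogen in the ring takes 5-ethylpyrimidin-2-yl in place of tert-butoxycarbonyl with no change beyond the scatter (a 1.1-fold higher number from compound 2 to compound 3 (0.02 log units; within the scatter)). Within the data shown here, the earlier compounds both carried tert-butoxycarbonyl, so this is the first sign that this position accepts a six-membered aromatic ring as well. No data at hand offer a reason for this result. Still open, as far as these compounds go, is whether a methyl or a cyclopropyl in place of the ethyl would keep the number. Also open, from the compounds shown here alone, is whether the fluoro step seen with tert-butoxycarbonyl carries over to the 5-ethylpyrimidin-2-yl series.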